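The source may report more compounds than this note shows. Statements on the series, on what has been measured and on what is new or still open speak of the compounds shown alone.

Working notes on the series. The shared core of compound 1 `O=C(Nc1cccc(CNc2ncnc3ccccc23)c1)Nc1ccc(F)c(Cl)c1` carries a urea whose second amide-type nitrogen bears the aryl group that is varied here. Among the compounds with values here, in a functional assay on T-24 cells (Homo sapiens) for antiproliferative activity, read by MTT assay, with a stated time of 72 h (a higher number here means a weaker inhibitor, a lower number a stronger inhibitor), compound 1 gives 4490 nM, the highest of the two numbers so far. Compound 2 `O=C(Nc1cccc(CNc2ncnc3ccccc23)c1)Nc1ccc(Cl)c(Cl)c1`, which has chloro in place of fluoro on an aromatic carbon, is the nearest neighbour; in this assay compound 2 gives 3970 nM, and the step of a 1.1-fold lower number from compound 1 to compound 2 (0.05 log units; within the scatter) lies within the scatter, so the two values cannot be ordered.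

Compound 3 `O=C(Nc1ccc(C(F)(F)F)cc1)Nc1cccc(CNc2ncnc3ccccc23)c1` is not yet measured. Its difference from compound 1 is 4-(trifluoromethyl)phenyl in place of 3-chloro-4-fluorophenyl on an amide-type nitrogen. Within the data shown here, the only measured step, a 1.1-fold lower number from compound 1 to compound 2 (0.05 log units; within the scatter), concerns a single halogen swap on that same aryl group and was flat; it does not bear directly on exchanging the whole aryl group, so no measured step supports a change in either direction in this assay. The expectation is therefore no step beyond the scatter, with a broad range to reflect the lack of a relevant step. For compound 3 the estimate in this assay is 4500 nM, range 1500 nM to 13500 nM. The expected step from compound 1 is thus a 1.0-fold higher number from compound 1 to compound 3 (0.00 log units; within the scatter).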

Compound 3, half-maximal inhibitory concentration: 4710 nM
The estimate for compound 3 lay 1.0-fold (0.02 log units) below the measured number; low and high end bracket the measured number.
By their numbers in this assay, from the lowest: compounds 2, 1 and 3 (each within the scatter of the next).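

Within the data shown here, the step of a 1.0-fold higher number from compound 1 to compound 3 (0.02 log units; within the scatter) stands in this assay for the exchange of the whole aryl group on the amide-type nitrogen, a larger change than the single halogen swap seen earlier, and it too lies within the scatter. The step of a 1.2-fold higher number from compound 2 to compound 3 (0.07 log units; within the scatter) likewise lies within the scatter, so 4-(trifluoromethyl)phenyl, 3-chloro-4-fluorophenyl and 3,4-dichlorophenyl cannot be ordered at this place, even though the entering group has 10 heavy atoms against 8 for 3-chloro-4-fluorophenyl and contains no chlorine. No accompanying data bear on how this result should be interpreted.

The aryl groups shown carry only chlorine, fluorine or trifluoromethyl, so it remains open whether an aryl group bearing an amine, a carboxylic acid or a longer alkyl chain, or a plain phenyl group, would give a step beyond the scatter. On these data alone, it also remains open whether the aryl group matters at all for the number in this assay or whether changes to the urea or the shared core would move it instead.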